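A few compounds are considered here, and "the series" means these few. Any claim that something is new, unique, unknown or untested is made for them only; others in the source may bear on it.

Two ureas carrying the same shared core have been measured in an ADME assay on the whole organism with Oryza sativa as the target, tested at 10 uM; a lower number here means a stronger effect, a higher number a weaker effect of the compound at the concentration tested. Compound 1, `CC(C)c1ccc(NC(=O)N[C@H](C)c2ccccc2)cc1`, bears an isopropyl on an aromatic carbon and gives 49% in this assay. Among the compounds with values here, compound 2, `CCCCCCCc1ccc(NC(=O)N[C@H](C)c2ccccc2)cc1`, carries a heptyl in that place instead and gives 100%, which is the higher of the two numbers; the single measured step is a number 51 percentage points higher from compound 1 to compound 2 (beyond the scatter), and it lies well beyond the scatter.

The next compound, compound 3, `C[C@@H](NC(=O)Nc1ccc(F)cc1)c1ccccc1`, takes the change (fluoro in place of heptyl on an aromatic carbon). Within the data shown here, the only measured step that bears on this change is the one from compound 1 to compound 2, where replacing a small alkyl with the long heptyl chain raised the number by a large amount. Fluoro is a far smaller group than either, so a step of comparable size in the opposite direction is expected, with the number for compound 3 landing near or somewhat under the value of compound 1. The expected step is a number 60 percentage points lower from compound 2 to compound 3 (beyond the scatter). Compound 3 is estimated at 40% in this assay, with a range from 15% to 70%.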

Compound 3, a percentage reported as activity, at one concentration (the size of the read-out at that concentration, not a potency): 92%
For compound 3 the middle estimate is 52 percentage points below the measured one, outside the stated range (above it).
By their numbers in this assay, from the lowest: compound 1; then compounds 3 and 2 (each within the scatter of the next).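

In this assay, the step of a number 8 percentage points lower from compound 2 to compound 3 (within the scatter) shows that on this aromatic carbon, fluoro in place of heptyl does not give a change that can be told from the scatter, so the long chain is not needed for the high number. The step of a number 43 percentage points higher from compound 1 to compound 3 (beyond the scatter) shows that compound 1 is the one set apart, and the number does not simply follow the size of the group: fluoro and heptyl, the smallest and largest of the three groups, both go against such a trend by standing on the same side of isopropyl. Nothing measured alongside these numbers gives an explanation for this result.

From the compounds shown here alone, what remains open is whether the lower number belongs to isopropyl alone or is shared by other groups at this place, such as a tert-butyl, a cyclopropyl or an ethyl. Going by these compounds, it is also open whether a propyl or butyl chain would stay close to compound 1 or close to compound 2, and whether a chloro or a methoxy would sit with compound 3.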